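Lengthening the Carbonyl Side Chain of Compound 3

This account rests on a few compounds, and the source may have more. Where it says the series, first, only, none or still open, it means among the compounds named here.

Among the measured compounds shown here, in a functional assay on A549 cells (Homo sapiens) for antiproliferative activity, read by MTT assay, with a stated time of 72 h (on this read-out higher numbers stand for weaker inhibition and lower numbers for stronger inhibition), compound 3 `C/C=C/C(=O)Nc1cccc(Oc2nc(Nc3cccc(OC)c3)nc3c2CSCC3)c1` gives 21100 nM, the lowest number so far, while compound 2 `C=C(C)C(=O)Nc1cccc(Oc2nc(Nc3ccn(C)n3)nc3c2CSCC3)c1` gives 46900 nM. Compound 1 `C/C=C/C(=O)Nc1cccc(Oc2nc(Nc3ccn(C)n3)nc3c2CSCC3)c1` gives > 50000 nM, which is a limit of the assay and not a number.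

Compound 4 `CCC/C=C/C(=O)Nc1cccc(Oc2nc(Nc3cccc(OC)c3)nc3c2CSCC3)c1` carries ethyl in place of hydrogen on a saturated chain carbon bound to a double-bonded chain carbon, which turns prop-1-en-1-yl into pent-1-en-1-yl. For the measured compounds named here, the closest precedent is 1-methylethenyl in place of prop-1-en-1-yl on a carbonyl carbon, which gave an at least 1.0-fold lower number from compound 1 to compound 2 (0.02 log units; that floor lies within the scatter). The change of 3-methoxyphenyl in place of 1-methyl-1H-pyrazol-3-yl gave an at least 2.3-fold lower number from compound 1 to compound 3 (0.37 log units; beyond the scatter), but it lies on a nitrogen on an aromatic ring and bears less directly.

The expected result is a 1.1-fold lower number from compound 3 to compound 4 (0.02 log units; within the scatter), with no shift beyond the scatter. For compound 4 the estimated value is 20000 nM, within an expected range of 8000 nM to 50000 nM.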

Compound 4, half-maximal inhibitory concentration: 11800 nM
Estimate against measurement, compound 4: 1.7-fold (0.23 log units) above; measured number inside the range.
By their numbers in this assay, from the lowest: compounds 4 and 3 (each within the scatter of the next); then compound 2. At a limit, above all of these: compound 1.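

In this assay there is a 1.8-fold lower number from compound 3 to compound 4 (0.25 log units; within the scatter) and so the side chain carries ethyl in place of hydrogen on a saturated chain carbon bound to a double-bonded chain carbon with no shift beyond the scatter. Among the compounds shown here, this is the first step on this side chain read between two actual numbers. The earlier step there started from compound 1, whose value is a limit and not a number: the limit of > 50000 nM in this assay, at which 1 of the 4 values shown sits.

On these data alone, whether a longer chain or an amine at the chain end would shift the number beyond the scatter stays open. So does whether pent-1-en-1-yl gives the same result with 1-methyl-1H-pyrazol-3-yl on the nitrogen.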